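Exchanging 3-aminophenyl for 4-chlorophenyl in the series

The compounds below may be only part of what the source reports. "The series", "measured", "known", "first", "only" and "open" are said of these compounds alone.

Of the compounds shown here, three have been measured so far in a functional assay on A549 cells (Homo sapiens) for antiproliferative activity, read by MTT assay, with a stated time of 72 h (a lower number here means a stronger inhibitor, a higher number a weaker inhibitor), and only one gives a true number. Compound 1 (`COc1cc(-c2ncnn2-c2cccc(N)c2)cc(OC)c1OC`) reads > 10000 nM as a limit of the assay and not a number. Compound 3 (`COc1cc(-n2ncnc2-c2ccc(OC(F)(F)F)cc2)cc(OC)c1OC`) reads > 10000 nM as a limit as well. Compound 2 (`CCOc1ccc(-c2ncnn2-c2cc(OC)c(OC)c(OC)c2)cc1Cl`) gives 10 nM in the same test. Compound 1 therefore stands at the limit of > 10000 nM in this assay, at which 2 of the 3 values shown sit, with no firmer reading.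

The next entry is compound 4 (`COc1cc(-c2ncnn2-c2ccc(Cl)cc2)cc(OC)c1OC`), which keeps the core of compound 1 and carries 4-chlorophenyl in place of 3-aminophenyl on an aromatic nitrogen. Going by the values given here, no measured pair isolates this change, so any expectation is loose. Among the compounds with values here, compound 2 at 10 nM is the only measured compound bearing chlorine, yet its groups are arranged differently from those of compound 4, so only a partial move towards stronger inhibition is expected. The expected size of the move is an at least 3.3-fold lower number from compound 1 to compound 4 (0.52 log units; beyond the scatter) in that direction, and the reading may well stay at the limit. For compound 4 the estimated value is 3000 nM with 150 nM to 10000 nM as the expected range.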

Compound 4, half-maximal inhibitory concentration: > 10000 nM
Compound 4: a limit, no number (the forecaster's own chance of this, stated with the estimate: 45%); middle value at least 3.3-fold (0.52 log units) from the limit.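

Compound 1 and compound 4 both read as a limit of the assay and not as a number, so no step can be read between them: the limit of > 10000 nM in this assay, at which 3 of the 4 values shown sit.

The compounds shown leave open whether 4-chlorophenyl in place of 3-aminophenyl on an aromatic nitrogen changes the reading at all, and by how much.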